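The source may hold more compounds than are shown below. What is called first, only, known or untested is meant among the compounds shown, and "the series" means these compounds.

Working notes on the series, read in a functional assay on MT4 cells (Homo sapiens) for cytotoxicity; on this read-out lower numbers stand for stronger inhibition and higher numbers for weaker inhibition. Compound 1 (`N#Cc1c(N)cccc1S(=O)(=O)c1ccccc1`) gives > 5000 nM, which is a limit and not a number. Compound 2 (`COc1cccc(S(=O)(=O)c2cccc(N)c2C#N)c1`) gives > 200000 nM, which is also a limit, so compound 2 stands without a measured number in this assay.

Compound 3 (`COc1cc(C)cc(S(=O)(=O)c2cccc(N)c2C#N)c1`) differs from compound 2 by one change: methyl in place of hydrogen on an aromatic carbon. This puts a methyl in place of hydrogen on an aromatic carbon, meta to a methoxy group.

Within the data shown here, the only measured step that bears on this is a step that the two limits leave unreadable from compound 1 to compound 2, a methoxy in place of hydrogen, and it carries no usable size. With nothing to carry over from that step, no shift beyond the scatter is expected in either direction. The expected step is a number no higher from compound 2 to compound 3 (the limit leaves the size open). For compound 3 the estimated value is 200000 nM, with an expected range from 80000 nM to 400000 nM, and the assay may well report only a limit.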

Compound 3, half-maximal inhibitory concentration: 94000 nM
For compound 3 the middle estimate is 2.1-fold (0.33 log units) above the measured one, and the stated range covers the measured number.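

In this assay, placing methyl on this aromatic carbon, meta to a methoxy group, gives an at least 2.1-fold lower number from compound 2 to compound 3 (0.32 log units; beyond the scatter). Among these compounds, this is the first step with a readable direction, and it runs toward stronger inhibition on this read-out, so this position is not silent to a single added carbon. The step's full size stays open because its starting point is a limit and not a number: the limit of > 200000 nM in this assay, at which 1 of the 3 values shown sits.

The step from compound 1 to compound 2 cannot be read, so the compounds shown do not tell whether the methoxy group itself shifts the value, or whether the methyl step depends on that group. Also open, from the compounds shown here alone, is whether an amine, a carboxylic acid or a longer chain at the same position would move the value further or reverse the step.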